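Ethyl at the core position: Vero cytotoxicity outlook

The source may hold more compounds than are shown below. What is called first, only, known or untested is meant among the compounds shown, and "the series" means these compounds.

Measured compounds:
- compound 1, `COc1ccc(CNc2ncnc(-c3ccco3)c2[N+](=O)[O-])cc1`: "not determined" (no result reported)
- compound 2, `COc1ccc(CNc2ncnc(-c3ccco3)c2NC=O)cc1`: > 40 ug/mL

Compound 1 carries a nitro group on the shared core and has no result in an ADME assay on Vero cells (Chlorocebus sabaeus) for cytotoxicity, read by MTT assay, with a stated time of 72 h; a higher number here means a weaker inhibitor, a lower number a stronger inhibitor; compound 1 gives "not determined" (no result reported). Among the compounds with values here, compound 2, the formylamino analogue, is the only compound with a reading. In this assay compound 2 gives > 40 ug/mL, which is a limit of the assay and not a number. Compound 2 therefore sits at the limit of > 40 ug/mL in this assay, at which 1 of the 2 values shown sits; nothing else in the series gives a single number to set it against.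

Compound 3, `CCc1nc(NCc2ccc(OC)cc2)c(NC=O)c(-c2ccco2)n1`, is not yet measured. It differs from compound 2 by ethyl in place of hydrogen on an aromatic carbon of the six-membered ring with two nitrogen, between the two ring nitrogen atoms. Within the data shown here, no measured step of this kind exists, so the size of the change cannot be read from the data. Since compound 2 only reaches a limit, the step that the limit leaves unreadable from compound 2 to compound 3 is expected to be none beyond the scatter, most likely again ending at the limit. For compound 3 the estimated value is 45 ug/mL with a range from 20 ug/mL to 100 ug/mL.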

Compound 3, half-maximal inhibitory concentration: > 40 ug/mL
Compound 3 ended at the assay's limit; the forecaster's own chance of this, stated with the estimate: 70%; the middle value does not contradict the limit.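

In this assay, compound 2 and compound 3 both end at a limit of the assay and not at a number, so no step between them can be read: the limit of > 40 ug/mL in this assay, at which 2 of the 3 values shown sit.

The compounds shown leave open whether ethyl in place of hydrogen on an aromatic carbon has any effect on the reading, since neither compound gives a single number.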